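The source may report more compounds than this note shows. Statements on the series, on what has been measured and on what is new or still open speak of the compounds shown alone.

Series notes, measured in a functional assay on the whole organism with Mus musculus as the target; on this read-out higher numbers stand for an effect only at larger amounts of compound and lower numbers for an effect already at smaller amounts:

- compound 1 `CNC(=O)/C=C(\C)c1cccc(C(F)(F)F)c1`: 87.5 mg/kg
- compound 2 `CN1C(=O)CCC1(O)c1cccc(C(F)(F)F)c1`: 93.8 mg/kg

The two values lie within the usual scatter of each other, so compound 2 and compound 1 cannot be told apart on this read-out. Among the measured compounds shown here, the two compounds also differ in more than one place, so the series offers no measured single-place step to use as a precedent.

The next compound is compound 3 `CCCN1C(=O)CCC1(O)c1cccc(C(F)(F)F)c1`. It carries ethyl in place of hydrogen on a saturated chain carbon bound to an amide-type nitrogen in a ring, which, cut one bond further out, reads methyl to propyl (ethyl in place of hydrogen on a saturated chain carbon bound to an amide-type nitrogen in a ring).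

For the measured compounds named here, the only anchor for this change is compound 2 at 93.8 mg/kg. In this assay, no step beyond the scatter is expected, with any drift more likely towards smaller doses, though the data give little support for that direction. The estimated step is a 1.3-fold lower number from compound 2 to compound 3 (0.13 log units; within the scatter), and the uncertainty around it is wide.

The estimate for compound 3 is 70 mg/kg, with an expected range of 30 mg/kg to 160 mg/kg.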

Compound 3, dose for half-maximal effect: > 200 mg/kg
Compound 3 was reported as a limit; the forecaster's own chance of this, stated with the estimate: 10%; middle value at least 2.8-fold (0.45 log units) away from the limit.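

Compounds 1 and 2 differ in more than one place and gave no reading of this position, whereas methyl to propyl is a single-place change and is not neutral in this assay: there is an at least 2.1-fold higher number from compound 2 to compound 3 (0.32 log units; beyond the scatter). Compound 3 gives > 200 mg/kg, which is a limit of the assay and not a number. The size of the step is thus fixed on one side only, and the reading at this place rests on one pair of compounds and on this limit: the limit of > 200 mg/kg in this assay, at which 1 of the 3 values shown sits.

From the compounds shown here alone, what remains open is how the read-out follows chain length at this place, since methyl and propyl alone cannot show whether the shift to larger doses builds gradually or appears abruptly, and a longer chain such as butyl, or a chain ending in an amine or a carboxylic acid, would fall outside what these compounds cover. Among the compounds shown here, also open is whether the same change would give a step of this kind on the core of compound 1, which offers no matching pair here.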